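The compounds below may be only part of what the source reports. "The series", "measured", "known", "first", "only" and "open" are said of these compounds alone.

Compound 1 `COc1nc2ccc(Br)cc2cc1C(c1ccccc1)n1cc(-c2ccccc2)nn1` gives 13.7% in an ADME assay on SK-OV-3 cells (Homo sapiens) for cytotoxicity, read by sulforhodamine B assay, with a stated time of 48 h, tested at 10 uM; a lower number here means less inhibition, a higher number more inhibition at the concentration tested (going by the name of the read-out). Compound 2 `COc1nc2ccc(Br)cc2cc1C(c1ccccc1)n1cc(CO)nn1` gives 3.23%. Compound 3 `COc1nc2ccc(Br)cc2cc1C(c1ccccc1)n1cc(-c2ccccc2C(F)(F)F)nn1` gives 9.55%.

Of the three numbers, compound 3 stands second highest, and the steps of a number 4.2 percentage points lower from compound 1 to compound 3 (within the scatter) and a number 6.3 percentage points higher from compound 2 to compound 3 (within the scatter) both lie within the scatter. Compound 4 `COc1nc2ccc(Br)cc2cc1C(c1ccccc1)n1cc(CCCCCO)nn1` differs from compound 3 in one place: 5-hydroxypentyl in place of 2-(trifluoromethyl)phenyl on an aromatic carbon. Among the compounds with values here, the one step beyond the scatter in this set, a number 10.5 percentage points lower from compound 1 to compound 2 (beyond the scatter), likewise replaced an aromatic ring with a hydroxymethyl group, and the number went down. The step of a number 6.3 percentage points higher from compound 2 to compound 3 (within the scatter) ran the other way but stayed within the scatter. A small drop is therefore expected, a number 4.6 percentage points lower from compound 3 to compound 4 (within the scatter). Compound 4 is estimated at 5%, in the range 0% to 12%.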

Compound 4, a percentage reported as inhibition, at one concentration (the size of the read-out at that concentration, not a potency): 8.69%
Beside the measured number, compound 4's estimate is 3.7 percentage points below it; low and high end bracket the measured number.
By their numbers in this assay, from the lowest: compounds 2, 4, 3 and 1 (each within the scatter of the next, the first and the last beyond it).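

At this carbon of the five-membered ring, a flexible chain ending in hydroxy can stand in for an aromatic ring in this assay without a readable difference: both a number 0.9 percentage points lower from compound 3 to compound 4 (within the scatter) and a number 5 percentage points lower from compound 1 to compound 4 (within the scatter) are printed as such. Chain length shows no clear effect either, with a number 5.5 percentage points higher from compound 2 to compound 4 (within the scatter) for 5-hydroxypentyl against hydroxymethyl. No measured evidence here explains these numbers.

On these data alone, whether an amine, a carboxylic acid or a longer chain at this carbon would move the number beyond the scatter remains open.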